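From propyl to isopropyl on a sulfur

The source may report more compounds than this note shows. Statements on the series, on what has been measured and on what is new or still open speak of the compounds shown alone.

Measured in a functional assay on K562 cells (Homo sapiens) for cytotoxicity, read by MTT assay; on this read-out lower numbers stand for stronger inhibition and higher numbers for weaker inhibition:
Compound 1 (`CC1=CCC[C@H]2[C@](C)(CC3=CC(=O)C(SC(C)(C)C)=CC3=O)[C@@H](C)CC[C@]12C`) gives 25700 nM
Compound 2 (`CCCSC1=CC(=O)C(C[C@]2(C)[C@@H](C)CC[C@]3(C)C(C)=CCC[C@@H]23)=CC1=O`) gives 45500 nM

Among the measured compounds shown here, of these two numbers, the one for compound 2 lies within the scatter of the one for compound 1. Compound 3 (`CC1=CCC[C@H]2[C@](C)(CC3=CC(=O)C(SC(C)C)=CC3=O)[C@@H](C)CC[C@]12C`) differs from compound 2 by one change (isopropyl in place of propyl on a sulfur), isopropyl in place of propyl on a sulfur. For the measured compounds named here, the only measured step bearing on it (a 1.8-fold higher number from compound 1 to compound 2 (0.25 log units; within the scatter)) exchanged tert-butyl for propyl on a sulfur and stayed within the scatter. For compound 3, no step beyond the scatter is therefore expected in this assay. The estimated step is small (a 1.3-fold lower number from compound 2 to compound 3 (0.13 log units; within the scatter)). Compound 3 is expected at 34000 nM (range 17000 nM to 68000 nM).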

Compound 3, half-maximal inhibitory concentration: 47500 nM
Compound 3: the middle estimate sits 1.4-fold (0.15 log units) below what was measured; the measured number falls inside the stated range.
By their numbers in this assay, from the lowest: compounds 1, 2 and 3 (each within the scatter of the next).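

In this assay, the step with isopropyl in place of propyl on the sulfur is a 1.0-fold higher number from compound 2 to compound 3 (0.02 log units; within the scatter), and the step with hydrogen in place of methyl on the saturated chain carbon bound to the sulfur is a 1.8-fold higher number from compound 1 to compound 3 (0.27 log units; within the scatter). Propyl, isopropyl and tert-butyl on this sulfur therefore all lie within the scatter of one another. No measurement offers an explanation for this. As far as these compounds go, whether a longer chain, a phenyl ring, an amine or a carboxylic acid on this sulfur would shift the number beyond the scatter remains open.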